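From Bromo to 4-Fluorophenyl on the Amide Aryl Ring

The source may hold more compounds than are shown below. What is called first, only, known or untested is meant among the compounds shown, and "the series" means these compounds.

For the measured compounds named here, compound 2 `O=C(CCc1cccc2c1B(O)OC2)Nc1cccc(Br)c1` is the only compound here with a number rather than a limit in a functional assay on MDA-MB-231 cells (Homo sapiens) for antiproliferative activity, read by MTT assay, with a stated time of 72 h; on this read-out higher numbers stand for weaker inhibition and lower numbers for stronger inhibition; in this assay compound 2 gives 720 nM. Compound 1 `CCNC(=O)CCc1cccc2c1B(O)OC2` reaches in this assay only a limit, > 100000 nM. Going by the values given here, the single measured step, an at least 130-fold lower number from compound 1 to compound 2 (2.14 log units; beyond the scatter), is large, though it rests on one value that is only a limit (the limit of > 100000 nM in this assay, at which 1 of the 2 values shown sits). Compound 3 `O=C(CCc1cccc2c1B(O)OC2)Nc1cccc(-c2ccc(F)cc2)c1` differs from compound 2 by 4-fluorophenyl in place of bromo on an aromatic carbon. Among the compounds with values here, the measured step concerns the same amide-type nitrogen but shows only that an aryl group there far outdoes ethyl; it says nothing about exchanging one group on that aryl ring for another. Within the data shown here, no measured step therefore speaks for a shift beyond the scatter, and compound 3 is expected to stay close to compound 2, with an estimated step of a 1.2-fold lower number from compound 2 to compound 3 (0.08 log units; within the scatter). Compound 3 is estimated at 600 nM, within a range from 150 nM to 2500 nM.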

Compound 3, half-maximal inhibitory concentration: 250 nM
Beside the measured number, compound 3's estimate is 2.4-fold (0.38 log units) above it, within the range that was stated.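

Putting 4-fluorophenyl in place of bromo gives a 2.9-fold lower number from compound 2 to compound 3 (0.46 log units; beyond the scatter) in this assay, a modest but real change. So the group on this aromatic carbon affects the read-out, not just the presence of an aryl ring on the amide nitrogen, and a whole aromatic ring can stand here in place of a single bromine atom without any loss of activity. This step also joins two true numbers, whereas the earlier step leans on compound 1, whose value is only a limit: the limit of > 100000 nM in this assay, at which 1 of the 3 values shown sits.

As far as these compounds go, it remains open whether the added ring or its fluorine carries the change, and a plain phenyl group at this place would separate the two. From the compounds shown here alone, how an amine or a carboxylic acid would read here also stays open, as does whether the change holds with a longer chain linking the amide to the core.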